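The source may hold more compounds than are shown below. What is called first, only, known or untested is meant among the compounds shown, and "the series" means these compounds.

Compound 1 `CC(/C=C/CC(C)CCCC(C)C)=C\C(=O)OC(C)C` and compound 2 `COC(CCC(C)C/C=C/C(C)=C/C(=O)OC(C)C)C(C)(C)OC` have both been measured in a physicochemical assay for lipophilicity; on this read-out lower numbers stand for lower lipophilicity and higher numbers for higher lipophilicity. In this assay compound 1 gives 7.15, the higher of the two numbers, while compound 2 gives 4.75, so the change a number 2.40 log units lower from compound 1 to compound 2 (beyond the scatter). Compound 3 `C#CCSC(=O)/C=C(C)/C=C/CC(C)CCCC(C)C` has not yet been measured; it differs from compound 1 only in the acid-side group: propargylsulfanyl in place of isopropoxy on a carbonyl carbon. Going by the values given here, the single measured step concerns a different part of the molecule and therefore bears only loosely on this change. The step from compound 1 to compound 3 is expected to be small, a number 0.15 log units lower from compound 1 to compound 3 (within the scatter), within the scatter. Compound 3 is thus estimated at 7, between 6.4 and 7.6.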

Compound 3, partition coefficient: 5.07
The estimate for compound 3 lay 1.93 log units above the measured number; measured number outside the range, below it.
By their numbers in this assay, from the lowest: compound 2; then compound 3; then compound 1.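

On the carbonyl carbon, the acid-side group matters in this assay: propargylsulfanyl in place of isopropoxy gives a number 2.08 log units lower from compound 1 to compound 3 (beyond the scatter), a large step. The two groups have the same heavy-atom, donor and acceptor counts, so those counts do not separate them; they differ in sulfur for oxygen and in the triple bond. No evidence here explains the size of this step.

Which of those two differences goes with the step stays open. A propylsulfanyl or a propargyloxy group on this carbonyl carbon would separate them.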